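Swapping hexyl for 2-(2-methoxyethoxy)ethoxy on compound 2

The source may report more compounds than this note shows. Statements on the series, on what has been measured and on what is new or still open speak of the compounds shown alone.

Compound 1 `CCCCCCNc1nc(=O)n([C@H]2C[C@H](O)[C@@H](CO)O2)cc1C` gives 90000 nM 
Compound 2 `CCCCCCCCNc1nc(=O)n([C@H]2C[C@H](O)[C@@H](CO)O2)cc1C` gives 90000 nM 
Compound 3 `CCCCCCCCCCCCNc1nc(=O)n([C@H]2C[C@H](O)[C@@H](CO)O2)cc1C` gives 158000 nM 

In an ADME assay on A549 cells (Homo sapiens) for cytotoxicity, read by MTT assay (on this read-out higher numbers stand for lower toxicity in this test and lower numbers for higher toxicity in this test), compound 2 gives 90000 nM and stands level with compound 1 (90000 nM). In compound 4 `COCCOCCOCCNc1nc(=O)n([C@H]2C[C@H](O)[C@@H](CO)O2)cc1C` the chain changes (2-(2-methoxyethoxy)ethoxy in place of hexyl on a saturated chain carbon, two bonds along the chain from a nitrogen on an aromatic ring): 2-(2-methoxyethoxy)ethoxy in place of hexyl on a saturated chain carbon, two bonds along the chain from a nitrogen on an aromatic ring. The measured steps that bear on this only lengthen the chain: no change at the digits printed from compound 1 to compound 2 (within the scatter) and a 1.8-fold higher number from compound 2 to compound 3 (0.24 log units; within the scatter) are both within the scatter. Neither tests this new group, so the expectation is loose, and no step beyond the scatter is expected in this assay here. The expected step is a 1.4-fold higher number from compound 2 to compound 4 (0.16 log units; within the scatter) as an estimate only. For compound 4 the estimated value is 130000 nM (range 60000 nM to 300000 nM).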

Compound 4, half-maximal cytotoxic concentration: 90000 nM
For compound 4 the middle estimate is 1.4-fold (0.16 log units) above the measured one; the range from low to high includes it.
By their numbers in this assay, from the lowest: compounds 1, 2, 4 and 3 (each within the scatter of the next).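

The earlier compounds shown here varied only the length of an all-carbon chain. In this assay, 2-(2-methoxyethoxy)ethoxy in place of hexyl gives no change at the digits printed from compound 2 to compound 4 (within the scatter) and in place of butyl gives no change at the digits printed from compound 1 to compound 4 (within the scatter), so putting oxygen atoms into the chain at this position, not just changing its length, leaves the read-out within the scatter. No evidence here explains this result. Still open, going by these compounds, is whether an amine or a carboxylic acid at the end of this chain, or a much shorter chain such as ethyl, would give a step beyond the scatter.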